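From 3,4-dimethoxyphenyl to 3-fluoro-4-hydroxyphenyl on a shared core

The source may report more compounds than this note shows. Statements on the series, on what has been measured and on what is new or still open speak of the compounds shown alone.

In a functional assay on MCF7 cells (Homo sapiens) for antiproliferative activity, read by sulforhodamine B assay, with a stated time of 48 h (a lower number here means a stronger inhibitor, a higher number a weaker inhibitor), compound 1 `COc1cc(C=C(C(=O)/C=C/c2cccc(OC)c2OC)C(=O)/C=C/c2cccc(OC)c2OC)cc(OC)c1O` gives 460 nM and compound 2 `COc1ccc(OC)c(/C=C/C(=O)C(=Cc2ccc(O)c(OC)c2)C(=O)/C=C/c2cc(OC)ccc2OC)c1` gives 400 nM, two values within the scatter of each other. Compound 3 `COc1ccc(OC)c(/C=C/C(=O)C(=Cc2ccc(OC)c(OC)c2)C(=O)/C=C/c2cc(OC)ccc2OC)c1` stands at 850 nM, which lies within the scatter of compound 1 but beyond it from compound 2.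

Compound 4 `COc1ccc(OC)c(/C=C/C(=O)C(=Cc2ccc(O)c(F)c2)C(=O)/C=C/c2cc(OC)ccc2OC)c1` departs from compound 3 in one place: on a double-bonded chain carbon bound to a double-bonded chain carbon, 3-fluoro-4-hydroxyphenyl takes the place of 3,4-dimethoxyphenyl (3-fluoro-4-hydroxyphenyl in place of 3,4-dimethoxyphenyl on a double-bonded chain carbon bound to a double-bonded chain carbon).

Within the data shown here, one measured step bears on this change: a 2.1-fold higher number from compound 2 to compound 3 (0.33 log units; beyond the scatter), where a methyl replaces a hydrogen on an oxygen on an aromatic ring. That step is modest. The group entering compound 4 carries such a hydrogen again, so a move in the opposite direction is expected in this assay. Among the measured compounds shown here, no measured compound carries fluorine, and that part of the change remains untested, which widens the uncertainty.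

The expected shift is a 2.0-fold lower number from compound 3 to compound 4 (0.31 log units; beyond the scatter), towards a lower number and of about the size of the measured step. For compound 4 the estimated value is 420 nM, with an expected range from 170 nM to 1000 nM.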

Compound 4, half-maximal inhibitory concentration: 460 nM
For compound 4 the middle estimate is 1.1-fold (0.04 log units) below the measured one; measured number inside the range.
By their numbers in this assay, from the lowest: compounds 2, 1, 4 and 3 (each within the scatter of the next, the first and the last beyond it).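

In this assay, among these compounds, the full exchange of 3,4-dimethoxyphenyl for 3-fluoro-4-hydroxyphenyl on a double-bonded chain carbon bound to a double-bonded chain carbon gives a 1.8-fold lower number from compound 3 to compound 4 (0.27 log units; within the scatter) and so cannot be told apart from repeat scatter, even though the single methyl-for-hydrogen step at this place, a 2.1-fold higher number from compound 2 to compound 3 (0.33 log units; beyond the scatter), lay beyond it. The new comparison is fluoro in place of methoxy on an aromatic carbon, the first fluorine seen here, which gives a 1.2-fold higher number from compound 2 to compound 4 (0.06 log units; within the scatter) and shows that, with the hydroxy group kept, these two groups are not separated in this assay. No independent measurement accompanies these numbers, so nothing shown accounts for them.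

The compounds shown leave open whether a chloro group or a trifluoromethyl group could stand in the place of the fluoro group with a similar outcome, and whether an amine could take the place of the hydroxy group. They also leave open how a ring carrying fluoro with methoxy instead of hydroxy would compare with compound 3 and compound 4.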